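The source may report more compounds than this note shows. Statements on the series, on what has been measured and on what is new or still open speak of the compounds shown alone.

Working notes on the series.

Compound 1 `CC(C)N(Cc1cccc(C(=O)O)c1)C[C@H]1O[C@@H](n2cnc3c(N)ncnc32)[C@H](O)[C@@H]1O` carries isopropyl and a carboxy-substituted benzyl on the amine nitrogen of the shared core. In an assay on cells for inhibition of Nicotinamide N-methyltransferase (Homo sapiens), with stated times of 10 min and 30 min (on this read-out lower numbers stand for stronger inhibition and higher numbers for weaker inhibition), compound 1 returns only a limit, > 250000 nM, and not a number. Compound 2 `Nc1ncnc2c1ncn2[C@@H]1O[C@H](CN(CCCC(=O)O)Cc2ccc3ccccc3c2)[C@@H](O)[C@H]1O` pairs 3-carboxypropyl with a naphthylmethyl group on the same nitrogen. In this assay compound 2 likewise returns only a limit, > 250000 nM, and not a number. Where compound 2 stands among the shown values is therefore fixed only at the edge of the measurable range, which is the limit of > 250000 nM in this assay, at which 2 of the 2 values shown sit; no ranking among the two compounds can be drawn from this.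

Compound 3 `CC(C)N(Cc1ccc2ccccc2c1)C[C@H]1O[C@@H](n2cnc3c(N)ncnc32)[C@H](O)[C@@H]1O` has not been measured. Relative to compound 2 the change is isopropyl in place of 3-carboxypropyl on an amine nitrogen. No measured pair isolates this change, and both shown values are limits, so no direction can be read from the data. The step from compound 2 to compound 3 is expected to be a number no higher from compound 2 to compound 3 (the limit leaves the size open), nothing beyond the scatter. Compound 3 is estimated at 250000 nM, within 60000 nM to 600000 nM, most likely reported again as a limit.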

Compound 3, half-maximal inhibitory concentration: 130000 nM
Estimate against measurement, compound 3: 1.9-fold (0.28 log units) above; the range from low to high includes it.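

In this assay, among the compounds shown here, compound 3 gives the first number of the series, 130000 nM, so the change of isopropyl in place of 3-carboxypropyl on an amine nitrogen, with the naphthalen-2-yl group held fixed, can be read as an at least 1.9-fold lower number from compound 2 to compound 3 (0.28 log units; that floor lies within the scatter). With isopropyl held fixed, the change of naphthalen-2-yl in place of 3-carboxyphenyl on a saturated chain carbon bound to an amine nitrogen can be read as an at least 1.9-fold lower number from compound 1 to compound 3 (0.28 log units; that floor lies within the scatter). Compound 3, the only one of the three without a carboxylic acid, is also the only one that gives a number and not a limit, yet both steps are floors of open size that do not clear the scatter: the limit of > 250000 nM in this assay, at which 2 of the 3 values shown sit.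

From the compounds shown here alone, how far either step actually reaches remains unknown, and so does which of the two changes counts for more. An amide or a primary amine at the end of the chain, or a longer chain such as hexyl with no carboxylic acid, in place of 3-carboxypropyl would show whether the number follows the carboxylic acid itself or the chain that carries it.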